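Amine substituent swap and mouse microsomal stability

This account rests on a few compounds, and the source may have more. Where it says the series, first, only, none or still open, it means among the compounds named here.

Measured so far:
- compound 1 `Cc1cc(C)n(-c2nc(-c3ccccc3)c(C)c(=O)[nH]2)n1` gives 45% in an ADME assay on microsomes from liver (Mus musculus) for metabolic stability, with a stated time of 30 min; on this read-out higher numbers stand for a more stable compound and lower numbers for a less stable compound
- compound 2 `Cc1cc(C)n(-c2nc(C(F)(F)F)cc(=O)[nH]2)n1` gives > 99% in this assay, a limit of the assay and not a number
- compound 3 `Cc1cc(NC2CCOCC2)n(-c2nc(C(F)(F)F)cc(=O)[nH]2)n1` gives 93% in this assay

Compound 3 holds the higher of the two numbers seen in this assay; compound 1 lies well beyond the scatter below it, and compound 2 contributes only a limit. For the measured compounds named here, the single one-place step measured, a number at least 6 percentage points lower from compound 2 to compound 3 (that floor lies within the scatter), replaces a methyl with the (oxan-4-yl)amino group, and its floor sits within the scatter.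

Compound 4 `Cc1cc(Nc2ccc(F)cc2)n(-c2nc(C(F)(F)F)cc(=O)[nH]2)n1` is not yet measured. The change is 4-fluorophenyl in place of oxan-4-yl on a nitrogen on an aromatic ring. Going by the values given here, no measured step exchanges one substituent on that nitrogen for another, so only the step from compound 2 to compound 3 bears on it, and it shows that this position tolerates a large group with at most a small loss. Compound 1, which carries a phenyl elsewhere, sits far lower, but that is a different change and no pattern is claimed from it.

For compound 4 a step of a number 8 percentage points lower from compound 3 to compound 4 (within the scatter) is expected, that is no change beyond the scatter, giving an estimated 85% with a range from 60% to 99%.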

Compound 4, percent of the compound remaining: 96%
Compound 4: the middle estimate sits 11 percentage points below what was measured; the measured number falls inside the stated range.
By their numbers in this assay, from the lowest: compound 1; then compounds 3 and 4 (each within the scatter of the next). At a limit, above all of these: compound 2.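

The nitrogen substituent can now be compared directly: in this assay there is a number 3 percentage points higher from compound 3 to compound 4 (within the scatter), so the exchange of the non-aromatic oxan-4-yl ring for the aromatic 4-fluorophenyl ring gives no change that can be told from the scatter. The replacement of methyl on the aromatic carbon now has a second amino group behind it, with a number at least 3 percentage points lower from compound 2 to compound 4 (that floor lies within the scatter), so across both amines no loss beyond the scatter can be stated. Compound 2 stands at a limit of the assay and not at a number, so neither step from it has a known size: the limit of > 99% in this assay, at which 1 of the 4 values shown sits.

Both groups on this nitrogen are six-membered rings, so the compounds shown leave open how a short alkyl chain, a piperidin-4-yl group or a ring carrying a carboxylic acid would read in this assay. They also do not separate the fluorine from the ring that carries it, a question that a plain phenyl or a 4-chlorophenyl group on the same nitrogen would address.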